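Swapping phenoxy for hydrogen on the propyl chain

The source may hold more compounds than are shown below. What is called first, only, known or untested is meant among the compounds shown, and "the series" means these compounds.

In a functional assay on A549 cells (Homo sapiens) for antiproliferative activity, read by MTT assay, with a stated time of 48 h (on this read-out lower numbers stand for stronger inhibition of growth and higher numbers for weaker inhibition of growth), compound 1 `CCCCCCCCN(Cc1ccc(C(=O)NO)cc1)c1ncc(-c2ccc(C)cc2)s1` gives 4630 nM with an octyl chain on the shared core, compound 2 `CCCCN(Cc1ccc(C(=O)NO)cc1)c1ncc(-c2ccc(C)cc2)s1` gives 4780 nM with a butyl chain, and compound 3 `Cc1ccc(-c2cnc(N(CCCOc3ccccc3)Cc3ccc(C(=O)NO)cc3)s2)cc1` gives 2530 nM with a 3-phenoxypropyl chain. Compound 3 stands within the scatter of both other compounds, so the three values cannot be ranked. Compound 4 `CCCN(Cc1ccc(C(=O)NO)cc1)c1ncc(-c2ccc(C)cc2)s1` has hydrogen in place of phenoxy on a saturated chain carbon, three bonds along the chain from a nitrogen on an aromatic ring, which leaves a propyl chain.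

The closest evidence is a 1.9-fold lower number from compound 2 to compound 3 (0.28 log units; within the scatter) for the butyl chain and a 1.8-fold lower number from compound 1 to compound 3 (0.26 log units; within the scatter) for the octyl chain, and both lie within the scatter. Between the two plain chains, a 1.0-fold higher number from compound 1 to compound 2 (0.01 log units; within the scatter) also stays within it. The expected step is a 1.9-fold higher number from compound 3 to compound 4 (0.27 log units; within the scatter) and it is expected to remain within the scatter, with compound 4 close to the plain-chain compounds. In this assay the estimate for compound 4 is 4700 nM with an expected range of 2800 nM to 7900 nM across repeated measurements.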

Compound 4, concentration for 50% growth inhibition: 3310 nM
Estimate against measurement, compound 4: 1.4-fold (0.15 log units) above, and the stated range covers the measured number.
By their numbers in this assay, from the lowest: compounds 3, 4, 1 and 2 (each within the scatter of the next).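

In this assay, the change from 3-phenoxypropyl to propyl can now be read directly, and the step lies within the scatter (a 1.3-fold higher number from compound 3 to compound 4 (0.12 log units; within the scatter)). The propyl chain also stays within the scatter of both longer plain chains, butyl (a 1.4-fold lower number from compound 2 to compound 4 (0.16 log units; within the scatter)) and octyl (a 1.4-fold lower number from compound 1 to compound 4 (0.15 log units; within the scatter)), so at this place the four compounds do not separate, whether the chain carries phenoxy or not. Nothing measured alongside these numbers bears on why they read alike.

These compounds leave open whether a chain ending in an amine or a carboxylic acid would move the number beyond the scatter. They also leave open whether a chain shorter than propyl, such as ethyl or methyl, would do so.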